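Lengthening the side chain of compound 2

This account rests on a few compounds, and the source may have more. Where it says the series, first, only, none or still open, it means among the compounds named here.

Going by the values given here, in a functional assay on 3T3-L1 cells (Mus musculus), with a stated time of 6 days (a lower number here means that less compound is needed, a higher number that more compound is needed for the effect), compound 2 `COc1ccc2[nH]c(-c3nc(NCCN4CCCC4)c4ccccc4n3)c(C=O)c2c1` gives 310 nM, the lower of the two numbers so far, while compound 1 `CCN(CC)CCCCNc1nc(-c2[nH]c3ccc(OC)cc3c2C=O)nc2ccccc12` gives 920 nM. Compound 3 `COc1ccc2[nH]c(-c3nc(NCCCCN4CCCC4)c4ccccc4n3)c(C=O)c2c1` changes compound 2 on a saturated chain carbon, two bonds along the chain from a nitrogen on an aromatic ring: 2-(pyrrolidin-1-yl)ethyl in place of pyrrolidin-1-yl on a saturated chain carbon, two bonds along the chain from a nitrogen on an aromatic ring. Among the compounds with values here, the one measured step at that place, a 3.0-fold lower number from compound 1 to compound 2 (0.47 log units; beyond the scatter), put pyrrolidin-1-yl in place of 2-(diethylamino)ethyl. The new 2-(pyrrolidin-1-yl)ethyl largely reverses that swap, so a modest rise is expected, and the expected size is a 1.8-fold higher number from compound 2 to compound 3 (0.25 log units; within the scatter). For compound 3 the estimated value is 550 nM, with an expected range from 180 nM to 1600 nM.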

Compound 3, half-maximal effective concentration in the 3T3-L1 assay: 33 nM
For compound 3 the middle estimate is 17-fold (1.22 log units) above the measured one, outside the stated range (below it).
By their numbers in the 3T3-L1 assay, from the lowest: compound 3; then compound 2; then compound 1.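

At this position chain length matters: in the 3T3-L1 assay, with pyrrolidin-1-yl kept at the chain end, going from the ethyl to the butyl chain gives a 9.4-fold lower number from compound 2 to compound 3 (0.97 log units; beyond the scatter). With the butyl chain kept, in the 3T3-L1 assay pyrrolidin-1-yl in place of diethylamino gives a 28-fold lower number from compound 1 to compound 3 (1.45 log units; beyond the scatter), so the earlier step mixed two changes that pulled in opposite directions. In a physicochemical assay for solubility, in phosphate buffer, with a stated time of 24 h, at pH 7.4 (on this read-out lower numbers stand for lower solubility and higher numbers for higher solubility), compound 2 gives 56.4 ug/mL and compound 3 gives 73.3 ug/mL, and the lengthening gives a 1.3-fold higher number from compound 2 to compound 3 (0.11 log units; within the scatter).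

No available data explain the gain. Open, from the compounds shown here alone, is how a 3-(pyrrolidin-1-yl)propyl chain, a chain longer than butyl, or a piperidine at the chain end would compare.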